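Methyl to Hydrogen on the Ring: Clearance in Rat Microsomes

The source may report more compounds than this note shows. Statements on the series, on what has been measured and on what is new or still open speak of the compounds shown alone.

The measured compounds:
compound 1, `C[C@]1(O)C[C@](c2cccc(OC(F)(F)F)c2)([C@H](O)c2ccccn2)C1`, 50 mL/min/kg
compound 2, `O[C@H](c1ccccn1)[C@]1(c2cccc(OC(F)(F)F)c2)C[C@H](O)C1`, 117 mL/min/kg
compound 3, `C[C@]1(O)C[C@@](c2cc(C(F)(F)F)ccn2)([C@H](O)c2ccccn2)C1`, 117 mL/min/kg

All three were read in an ADME assay on liver for metabolic stability, with Liver microsome (Rattus norvegicus) as the target, read by LC-MS, using microsomes, with a stated time of 5 h; a higher number here means faster removal of the compound, a lower number slower removal. Compound 1 gives 50 mL/min/kg, and compound 2 gives 117 mL/min/kg. The two differ in one place, (hydrogen in place of methyl on a saturated ring carbon), and the step is a 2.3-fold higher number from compound 1 to compound 2 (0.37 log units; beyond the scatter). Compound 3 gives 117 mL/min/kg, level with compound 2 at the digits shown; compound 1 and compound 3 have different cores, and that difference is not broken down here.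

Compound 4, `O[C@H](c1ccccn1)[C@]1(c2cc(C(F)(F)F)ccn2)C[C@@H](O)C1`, has not yet been measured in this assay. It differs from compound 3 by hydrogen in place of methyl on a saturated ring carbon, the same change as from compound 1 to compound 2, made on the same kind of place on the core of compound 3. For the measured compounds named here, since that earlier step was a 2.3-fold higher number from compound 1 to compound 2 (0.37 log units; beyond the scatter), compound 4 is expected to show a step of roughly a 1.8-fold higher number from compound 3 to compound 4 (0.25 log units; within the scatter) from compound 3, with extra doubt because compound 3 already stands at 117 mL/min/kg, the highest number so far. Compound 4 is therefore estimated at 210 mL/min/kg, in the range 110 mL/min/kg to 420 mL/min/kg.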

Compound 4, clearance: 50 mL/min/kg
Compound 4: the middle estimate sits 4.2-fold (0.62 log units) above what was measured; the measured number lies below the stated range.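

In this assay, hydrogen in place of methyl on a saturated ring carbon gives a 2.3-fold lower number from compound 3 to compound 4 (0.37 log units; beyond the scatter). Set beside the earlier step, the same change runs in opposite directions on the two cores: the same change on two cores in this assay, a 2.3-fold higher number (0.37 log units; beyond the scatter) from compound 1 to compound 2 and a 2.3-fold lower number (0.37 log units; beyond the scatter) from compound 3 to compound 4, 5.5-fold (0.74 log units) apart, beyond the scatter of two such steps This shows that, among these four compounds, the step measured on one core cannot be carried over to the other, neither in size nor in direction, but it does not show which difference between the two cores lies behind the reversal, and one pair on each core is too little to support a rule for the series.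

The compounds shown leave open how a third core would respond to the same change, and how an ethyl group, a fluorine or an amine in place of the methyl on that saturated ring carbon would read in this assay. They also leave open whether the reversal would appear in any other read-out.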